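The source may hold more compounds than are shown below. What is called first, only, known or untested is meant among the compounds shown, and "the series" means these compounds.

In an ADME assay on Vero cells (Chlorocebus sabaeus) for inhibition (a lower number here means that less compound is tolerated, a higher number that more compound is tolerated), compound 1 `COc1ccc(/C=C2\CCC/C(=C\c3ccc(OC)cc3)C2=O)cc1` gives 178000 nM and compound 2 `COc1ccc(/C=C2\CCC/C(=C\c3ccc(N(C)C)cc3)C2=O)cc1` gives 392000 nM, the higher of the two numbers. Compound 3 `COc1ccc(/C=C2\CCC/C(=C\c3ccc([N+](=O)[O-])cc3)C2=O)cc1` differs from compound 2 by nitro in place of dimethylamino on an aromatic carbon. Within the data shown here, the one measured step bearing on this is the modest 2.2-fold higher number from compound 1 to compound 2 (0.34 log units; beyond the scatter), seen when dimethylamino took the place of methoxy, so losing dimethylamino in compound 3 is expected to bring a similarly modest move to a lower number in this assay. Among the measured compounds shown here, no compound with nitro has been measured yet. The expected step is a 2.3-fold lower number from compound 2 to compound 3 (0.36 log units; beyond the scatter). For compound 3 the estimated value is 170000 nM, with an expected range of 70000 nM to 400000 nM.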

Compound 3, half-maximal cytotoxic concentration: 435000 nM
Compound 3: the middle estimate sits 2.6-fold (0.41 log units) below what was measured; the measured number lies above the stated range.
By their numbers in this assay, from the lowest: compound 1; then compounds 2 and 3 (each within the scatter of the next).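

In this assay, nitro in place of dimethylamino on an aromatic carbon gives a 1.1-fold higher number from compound 2 to compound 3 (0.05 log units; within the scatter), so two very different groups cannot be told apart here. Nitro in place of methoxy gives a 2.4-fold higher number from compound 1 to compound 3 (0.39 log units; beyond the scatter), which joins a 2.2-fold higher number from compound 1 to compound 2 (0.34 log units; beyond the scatter) in setting compound 1 apart from the other two at this position. No measurement shown here accounts for this result. Going by these compounds, whether a primary amine, a carboxylic acid or fluorine at this place would match compound 2 and compound 3 remains open. So does whether replacing the remaining methoxy group would move the number.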